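Adding an Acetamido Group to a Pyrimidine Core

A few compounds are considered here, and "the series" means these few. Any claim that something is new, unique, unknown or untested is made for them only; others in the source may bear on it.

Of the compounds shown here, two have so far been tested in a functional assay on the whole organism for inhibition, with Rattus norvegicus as the target, with stated times of 1 h and 3.5 h, at a dose of 100 mg/kg by the oral route; a lower number here means less inhibition, a higher number more inhibition at the dose given (going by the name of the read-out). Compound 1 `Cc1cncnc1-c1ccccc1` gives 48% in this assay. Compound 2 `c1cc(-c2ccncn2)ccn1` gives 45% in this assay, a number that lies within the usual scatter of the number for compound 1, so the two stand together and neither can be called stronger or weaker.

Compound 3 `CC(=O)Nc1nccc(-c2ccncc2)n1` has not yet been measured. It differs from compound 2 in one place: acetamido in place of hydrogen on an aromatic carbon. For the measured compounds named here, no measured pair shows what such a change does in this assay, so the size of the step has to be guessed. With nothing pointing either way, the step from compound 2 to compound 3 is expected to stay within the scatter, that is no change at the digits printed from compound 2 to compound 3 (within the scatter). Compound 3 is therefore estimated to give 45% in this assay, with a plausible range from 20% to 70%.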

Compound 3, a percentage reported as inhibition, in the whole organism at one dose (the size of the read-out at that dose, not a potency): 52%
The estimate for compound 3 lay 7 percentage points below the measured number, and the stated range covers the measured number.
By their numbers in this assay, from the lowest: compounds 2, 1 and 3 (each within the scatter of the next).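

For the compounds shown here, on an aromatic carbon of the six-membered aromatic ring with 2 nitrogen, between two ring nitrogen atoms, acetamido in place of hydrogen gives a number 7 percentage points higher from compound 2 to compound 3 (within the scatter) in this assay, so this is the first view of what a substituent at this position does. The position can carry acetamido, a group of 4 heavy atoms in place of a lone hydrogen, and at this single oral dose the read-out still cannot tell compound 3 from compound 2. Nothing measured here bears on what lies behind this result.

From the compounds shown here alone, it remains open whether a plain amine at the same position, or a longer chain on the carbonyl such as propionamido, would shift the number beyond the scatter. A read-out at one dose also leaves open how these compounds would compare in potency.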